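Removing the Methyl Beside the Carboxy-Bearing Ring

The source may report more compounds than this note shows. Statements on the series, on what has been measured and on what is new or still open speak of the compounds shown alone.

Compound 3 `Cc1ccc(C(=O)O)cc1OCCCCOc1ccc(C(=O)CC(C)C)c(O)c1C` is one of three related compounds tested in an assay on HEK293 cells for positive allosteric modulation of metabotropic glutamate receptor 2 (Rattus norvegicus), read by thallium flux, with a stated time of 2.5 min; on this read-out higher numbers stand for larger maximal responses and lower numbers for smaller maximal responses. In this assay compound 3 gives 76.9%, the lowest of the three numbers. Compound 1 `Cc1c(OCCCCOc2ccc(C(=O)O)cc2F)ccc(C(=O)CC(C)C)c1O` gives 85% and compound 2 `Cc1c(OCCCCOc2ccc(C(=O)O)cc2Cl)ccc(C(=O)CC(C)C)c1O` gives 99.5%; the step of a number 8.1 percentage points lower from compound 1 to compound 3 (within the scatter) stays within the scatter, whereas a number 22.6 percentage points lower from compound 2 to compound 3 (beyond the scatter) lies beyond it. Compound 4 `Cc1c(OCCCCOc2cccc(C(=O)O)c2)ccc(C(=O)CC(C)C)c1O` differs from compound 3 by hydrogen in place of methyl on an aromatic carbon. Going by the values given here, no measured step tests this change by itself: a number 8.1 percentage points lower from compound 1 to compound 3 (within the scatter) and a number 22.6 percentage points lower from compound 2 to compound 3 (beyond the scatter) exchange the whole carboxy-bearing ring, halogen and methyl together, and a number 14.5 percentage points higher from compound 1 to compound 2 (beyond the scatter) swaps one halogen for another. Compound 4 is therefore expected to give about 78%, within 60% to 96%. The step of a number 1.1 percentage points higher from compound 3 to compound 4 (within the scatter) is thus estimated to stay within the scatter.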

Compound 4, largest response reached (reported as percent of maximum), in percent of the reference or control that the assay uses: 84.5%
Compound 4: middle estimate off by 6.5 percentage points, on the low side; the range from low to high includes it.
By their numbers in this assay, from the lowest: compounds 3, 4 and 1 (each within the scatter of the next); then compound 2.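

Taken alone, replacing the methyl with hydrogen gives no difference that can be told from scatter, with a number 7.6 percentage points higher from compound 3 to compound 4 (within the scatter). The 3-carboxyphenyl ring also cannot be told from the 4-carboxy-2-fluorophenyl ring, with a number 0.5 percentage points lower from compound 1 to compound 4 (within the scatter), but it falls short of the 4-carboxy-2-chlorophenyl ring, with a number 15 percentage points lower from compound 2 to compound 4 (beyond the scatter), so among these four compounds only compound 2 stands apart. No supporting evidence is available to explain these results. As far as these compounds go, whether an ethyl group, a methoxy group or an amine on this aromatic carbon would give a similar response remains open.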